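The compounds below may be only part of what the source reports. "The series", "measured", "known", "first", "only" and "open" are said of these compounds alone.

Compound 1, `Cn1ncc([N+](=O)[O-])c1C(=O)Nc1ccc2nc(NC(=O)C3CCCCC3)sc2c1`, gives 0.026 ug/mL in a functional assay on WI-38 VA13 cells (Homo sapiens) for cytotoxicity; on this read-out higher numbers stand for an effect only at larger amounts of compound and lower numbers for an effect already at smaller amounts.
Compound 2, `Cc1ccccc1C(=O)Nc1ccc2nc(NC(=O)C3CCCCC3)sc2c1`, gives 0.085 ug/mL in this assay.
Compound 3, `O=C(Nc1nc2ccc(NC(=O)C3CCCO3)cc2s1)C1CCCCC1`, gives 1.3 ug/mL in this assay.

Compound 3 thus stands highest of the three numbers in this assay, with compound 2 nearest and compound 1 furthest from it. Compound 4, `Cc1cc(C(=O)Nc2ccc3nc(NC(=O)C4CCCCC4)sc3c2)n(C)n1`, differs from compound 3 by 1,3-dimethyl-1H-pyrazol-5-yl in place of oxolan-2-yl on a carbonyl carbon. For the measured compounds named here, two measured steps bear on this exchange: a 50-fold higher number from compound 1 to compound 3 (1.70 log units; beyond the scatter) and a 15-fold higher number from compound 2 to compound 3 (1.18 log units; beyond the scatter), both large rises in this assay when a ring on the carbonyl carbon was replaced by oxolan-2-yl. Since compound 4 reverses that kind of exchange, a large fall is expected for compound 4, an 8.7-fold lower number from compound 3 to compound 4 (0.94 log units; beyond the scatter). Compound 4 is therefore estimated at 0.15 ug/mL in this assay, with a range from 0.04 ug/mL to 0.6 ug/mL.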

Compound 4, half-maximal effective concentration: 0.12 ug/mL
Estimate against measurement, compound 4: 1.3-fold (0.10 log units) above; the measured number falls inside the stated range.
By their numbers in this assay, from the lowest: compound 1; then compounds 2 and 4 (each within the scatter of the next); then compound 3.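

In this assay, the step of an 11-fold lower number from compound 3 to compound 4 (1.03 log units; beyond the scatter) shows that a third aromatic ring on this carbonyl carbon also stands well apart from oxolan-2-yl, so all of compounds 1, 2 and 4 lie below compound 3. The aromatic rings still differ among themselves: a 1.4-fold higher number from compound 2 to compound 4 (0.15 log units; within the scatter) cannot separate 1,3-dimethyl-1H-pyrazol-5-yl from 2-methylphenyl, while a 4.6-fold higher number from compound 1 to compound 4 (0.66 log units; beyond the scatter) separates the two pyrazole groups. No measurement shown explains these differences. From the compounds shown here alone, it remains open how a pyrazole carrying only the nitro group, or an amine or carboxylic acid on this ring, would compare.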